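Paw edema inhibition: expectation for a fourth compound

The compounds below may be only part of what the source reports. "The series", "measured", "known", "first", "only" and "open" are said of these compounds alone.

Compound 1 `COc1ccc(-c2nnc(SCC(=O)Nc3ccc(/C(C)=N/O)cc3)n2-c2ccccc2)cc1`: 45%
Compound 2 `CCn1c(SCC(=O)Nc2ccc(/C(C)=N/O)cc2)nnc1-c1ccccc1`: 54%
Compound 3 `COc1ccc(-c2nnc(SCC(=O)Nc3ccc(C(C)=O)cc3)n2-c2ccccc2)cc1`: 29%

In a functional assay on the whole organism (strain albino) for inhibition, with Rattus norvegicus as the target, read by paw edema, with stated times of 30 min and 1 h, at a dose of 0.28 mmol/kg by the oral route (a higher number here means more inhibition at the dose given (going by the name of the read-out), a lower number less inhibition), compound 2 gives 54%, a number that lies within the scatter of the value of compound 1, so no order between the two can be read. Compound 3 sits a number 16 percentage points lower from compound 1 to compound 3 (beyond the scatter); this step is a group of 3 heavy atoms (2 carbon, 1 oxygen; no ring) in place of a group of 4 heavy atoms (2 carbon, 1 nitrogen, 1 oxygen; no ring), on an aromatic carbon. The difference between the cores of compound 1 and compound 2 is not broken down here. Compound 4 `CCn1c(SCC(=O)Nc2ccc(C(C)=O)cc2)nnc1-c1ccccc1` is the unmeasured partner of compound 2 and differs from it by a group of 3 heavy atoms (2 carbon, 1 oxygen; no ring) in place of a group of 4 heavy atoms (2 carbon, 1 nitrogen, 1 oxygen; no ring), on an aromatic carbon, the same change at the same place. Compound 4 is expected to show a number 16 percentage points lower from compound 2 to compound 4 (beyond the scatter), because the same change gave a number 16 percentage points lower from compound 1 to compound 3 (beyond the scatter). Compound 4 is therefore estimated at 38%, with an expected range from 26% to 50%.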

Compound 4, a percentage reported as inhibition, in the whole organism at one dose (the size of the read-out at that dose, not a potency): 50%
Beside the measured number, compound 4's estimate is 12 percentage points below it, within the range that was stated.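

In this assay, the exchange for acetyl on the core of compound 2 gives a number 4 percentage points lower from compound 2 to compound 4 (within the scatter). Set beside the earlier step on the other core, the change shows no difference between the two cores that can be read: the same change on two cores in this assay, a number 16 percentage points lower (beyond the scatter) from compound 1 to compound 3 and a number 4 percentage points lower (within the scatter) from compound 2 to compound 4, 12 percentage points apart, within the scatter of two such steps. Going by these compounds alone, this does not establish a fixed size for the change, as each core offers only one pair, one step lies beyond the scatter and the other within it, and nothing here speaks for a third core.

The compounds shown leave open how an amine or a carboxylic acid on that aromatic carbon would read. They also leave open how the change would behave on a core carrying a longer chain.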